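Swapping One Saturated Ring Tail for Another

This account rests on a few compounds, and the source may have more. Where it says the series, first, only, none or still open, it means among the compounds named here.

Compound 1 `COc1cc2c(Nc3ccc(C#N)cc3)ncnc2cc1OCCCN1CCC(C)CC1` was tested in a functional assay on A549 cells (Homo sapiens) for antiproliferative activity, read by MTT assay, with a stated time of 72 h (a lower number here means a stronger inhibitor, a higher number a weaker inhibitor), where compound 1 gives 32300 nM. Compound 2 `COc1cc2c(Nc3ccc(C#N)cc3)ncnc2cc1OCCCN1CCC(N(C)C)CC1` gives 42400 nM in this assay. The step of a 1.3-fold higher number from compound 1 to compound 2 (0.12 log units; within the scatter) is within the scatter, so compound 1 and compound 2 sit together and neither can be called stronger. Compound 3 `COc1cc2c(Nc3ccc(C#N)cc3)ncnc2cc1OCCCN1CCN(C)CC1` differs from compound 1 in one place: 4-methylpiperazin-1-yl in place of 4-methylpiperidin-1-yl on a saturated chain carbon, three bonds along the chain from an oxygen on an aromatic ring. Among the compounds with values here, no measured step makes this exact change; the only step at hand, a 1.3-fold higher number from compound 1 to compound 2 (0.12 log units; within the scatter), altered the same saturated ring without moving the number beyond the scatter. The change is therefore expected to shift the number little, a 1.1-fold higher number from compound 1 to compound 3 (0.03 log units; within the scatter). Compound 3 is estimated at 35000 nM, with a range from 12000 nM to 100000 nM.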

Compound 3, half-maximal inhibitory concentration: 48800 nM
Compound 3: the middle estimate sits 1.4-fold (0.14 log units) below what was measured; the range from low to high includes it.
By their numbers in this assay, from the lowest: compounds 1, 2 and 3 (each within the scatter of the next).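

Setting 4-methylpiperazin-1-yl, a ring with 2 hetero atoms, in place of 4-methylpiperidin-1-yl gives a 1.5-fold higher number from compound 1 to compound 3 (0.18 log units; within the scatter) in this assay. Against 4-(dimethylamino)piperidin-1-yl, the same ring gives a 1.2-fold higher number from compound 2 to compound 3 (0.06 log units; within the scatter) and so also stays within the scatter, which means that none of these three saturated ring tails at the end of the chain can be called stronger. No available evidence bears on this result. Still open, from the compounds shown here alone, is whether a morpholin-4-yl ring, a carboxylic acid or a longer chain at this position would move the number beyond the scatter.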